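This account rests on a few compounds, and the source may have more. Where it says the series, first, only, none or still open, it means among the compounds named here.

In an ADME assay on HUVEC cells (Homo sapiens) for cytotoxicity, read by MTT assay, with a stated time of 24 h (a lower number here means a stronger inhibitor, a higher number a weaker inhibitor), compound 1 `CC(CC[C@H]1/C(=C/c2ccc(F)cc2)CC[C@H]2C(C)(C)CCC[C@]12C)CC(=O)O` gives > 200000 nM, which is a limit and not a number. Compound 2 `CC(CC[C@H]1/C(=C/c2ccc(Cl)cc2)CC[C@H]2C(C)(C)CCC[C@]12C)CC(=O)O` gives > 200000 nM, likewise a limit. Compound 2 therefore stands at the limit of > 200000 nM in this assay, at which 2 of the 2 values shown sit. Compound 3 `CC(CC[C@H]1/C(=C/c2ccc(I)cc2)CC[C@H]2C(C)(C)CCC[C@]12C)CC(=O)O` has iodo in place of chloro on an aromatic carbon, para to a large group: iodo in place of chloro on an aromatic carbon. Among the measured compounds shown here, the only measured step bearing on this change is a step that the two limits leave unreadable from compound 1 to compound 2, which gives no size to carry forward. The expected outcome in this assay is a step that the limit leaves unreadable from compound 2 to compound 3, with no shift beyond the scatter in either direction. For compound 3 the estimate is 220000 nM, with an expected range of 120000 nM to 400000 nM.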

Compound 3, half-maximal inhibitory concentration: 194000 nM
Estimate against measurement, compound 3: 1.1-fold (0.05 log units) above; the range from low to high includes it.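

In this assay, among the compounds shown here, compound 3, with its 4-iodophenyl group, gives the first number, whereas compounds 1 and 2 give only limits. With an at least 1.0-fold lower number from compound 2 to compound 3 (0.01 log units; that floor lies within the scatter) and an at least 1.0-fold lower number from compound 1 to compound 3 (0.01 log units; that floor lies within the scatter) the halogen change at this place has only floors, and no shift beyond the scatter is established. The two other values remain limits: the limit of > 200000 nM in this assay, at which 2 of the 3 values shown sit.

As far as these compounds go, the true size of both steps stays open, and the step from compound 1 to compound 2 cannot be read. Also open, from the compounds shown here alone, is how a methoxy group or an amine would read on this aromatic carbon.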